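This account rests on a few compounds, and the source may have more. Where it says the series, first, only, none or still open, it means among the compounds named here.

Going by the values given here, only two compounds have been tested so far, and only one of them gives a firm number. In a functional assay on SW480 cells (Homo sapiens) for antiproliferative activity, with a stated time of 72 h (a higher number here means a weaker inhibitor, a lower number a stronger inhibitor), compound 1 `O=C(COc1ccc(CNC2CC=C(c3c[nH]c4cccc(F)c34)CC2)c(F)c1)NO` gives 189 nM as its reading. Compound 2 `Cc1[nH]c2ccccc2c1C1=CCN(C(=O)c2ccc(OCC(=O)NO)cc2)CC1` gives > 5000 nM in this assay and that reading is a limit of the assay, not a number.

The next compound to be tested is compound 3 `O=C(COc1ccc(C(=O)N2CC=C(c3c[nH]c4ccc(F)cc34)CC2)cc1)NO`. It carries 5-fluoro-1H-indol-3-yl in place of 2-methyl-1H-indol-3-yl on a double-bonded ring carbon and the rest of compound 2 stays the same. Among the compounds with values here, no two tested compounds differ in one place only, so the effect of this swap cannot be read from the data.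

The best guide is compound 2 itself, at > 5000 nM in this assay as its limit, so compound 3 is expected to remain a weak inhibitor and may also return only a limit. A modest move towards stronger inhibition is expected, estimated as an at least 1.4-fold lower number from compound 2 to compound 3 (0.15 log units; that floor lies within the scatter) in this assay and perhaps no larger than the usual scatter. For compound 3 the estimate is 3500 nM with an expected range of 1000 nM to 10000 nM in this assay once it is measured.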

Compound 3, half-maximal inhibitory concentration: > 5000 nM
Compound 3 gave a limit, no number; the forecaster's own chance of this, stated with the estimate: 55%; middle value at least 1.4-fold (0.15 log units) from the limit.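

Compound 2 and compound 3 each give a limit in this assay, not a number, so the swap from 2-methyl-1H-indol-3-yl to 5-fluoro-1H-indol-3-yl yields no readable step: the limit of > 5000 nM in this assay, at which 2 of the 3 values shown sit.

The compounds shown leave open where the true readings of compound 2 and compound 3 lie, and so whether this swap changes antiproliferative activity at all.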